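The source may report more compounds than this note shows. Statements on the series, on what has been measured and on what is new or still open speak of the compounds shown alone.

Measured so far:
Compound 1 `O=C1N/C(=N/c2ccccc2)S/C1=C\c1ccccn1`: 29.2%
Compound 2 `O=C1N/C(=N/c2ccc(Cl)cc2)S/C1=C\c1ccccn1`: 41.7%

In a functional assay on the whole organism (strain Swiss albino) for inhibition, with Mus musculus as the target, in the writhing test, with stated times of 30 min and 15 min, at a dose of 50 mg/kg by the oral route (a higher number here means more inhibition at the dose given (going by the name of the read-out), a lower number less inhibition), compound 2 stands highest of the two numbers, the nearest being compound 1, with a rise a number 12.5 percentage points higher from compound 1 to compound 2 (beyond the scatter). Compound 3 `Cc1cccc(/N=C2/NC(=O)/C(=C/c3ccccn3)S2)c1` differs from compound 2 by 3-methylphenyl in place of 4-chlorophenyl on a double-bonded nitrogen. Within the data shown here, only one measured step exists, and it concerns chloro replacing hydrogen, so no step directly bears on exchanging 4-chlorophenyl for 3-methylphenyl. Since the single gain came with the chloro group, its loss is expected to cost a little, with compound 3 estimated at 35% within a range of 22% to 48%. For compound 3 this means an expected step of a number 6.7 percentage points lower from compound 2 to compound 3 (within the scatter), likely within the scatter.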

Compound 3, a percentage reported as inhibition, in the whole organism at one dose (the size of the read-out at that dose, not a potency): 52.3%
The estimate for compound 3 lay 17.3 percentage points below the measured number; measured number outside the range, above it.
By their numbers in this assay, from the lowest: compound 1; then compound 2; then compound 3.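

Among these compounds, compound 3 shows that chloro is not the only group on this aromatic ring linked to a higher number in this assay: methyl in place of hydrogen gives a number 23.1 percentage points higher from compound 1 to compound 3 (beyond the scatter), and 3-methylphenyl in place of 4-chlorophenyl gives a number 10.6 percentage points higher from compound 2 to compound 3 (beyond the scatter). This exchange alters both the group and where it sits on the ring, so these compounds cannot separate those two changes. Nothing here explains the rise. On these data alone, whether a methoxy group or an amine on the ring would give a higher or lower number remains open.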